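From piperidin-1-yl to diethylamino on the side chain

This account rests on a few compounds, and the source may have more. Where it says the series, first, only, none or still open, it means among the compounds named here.

Compound 1 `CN(C)CCN=C(Nc1ccc(C(=N)N)cc1)Nc1ccc(C(=N)N)cc1` and compound 2 `N=C(N)c1ccc(NC(=NCCN2CCCCC2)Nc2ccc(C(=N)N)cc2)cc1` differ in one group only. In an ADME assay on HEK293 cells (Homo sapiens) for cytotoxicity, read by resazurin assay, with a stated time of 24 h (a higher number here means a weaker inhibitor, a lower number a stronger inhibitor), compound 1 gives > 50000 nM, which is a limit and not a number. Compound 2 gives > 50000 nM, which is likewise only a limit. The data so far therefore amount to the limit of > 50000 nM in this assay, at which 2 of the 2 values shown sit.

Compound 3 `CCN(CC)CCN=C(Nc1ccc(C(=N)N)cc1)Nc1ccc(C(=N)N)cc1` has diethylamino in place of the piperidin-1-yl of compound 2, on a saturated chain carbon, two bonds along the chain from a double-bonded nitrogen: diethylamino in place of piperidin-1-yl on a saturated chain carbon, two bonds along the chain from a double-bonded nitrogen.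

Among the measured compounds shown here, the one measured step that bears on this is a step that the two limits leave unreadable from compound 1 to compound 2, so it offers no readable size. On that basis, no step beyond the scatter is expected in this assay. The expected change is a number no higher from compound 2 to compound 3 (the limit leaves the size open). The estimate for compound 3 is 50000 nM, with an expected range from 25000 nM to 100000 nM, and the assay will most likely again report only a limit.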

Compound 3, half-maximal inhibitory concentration: > 50000 nM
Compound 3: only a limit was reported (the forecaster's own chance of this, stated with the estimate: 85%); the middle value lies on the limit itself.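

In this assay, among the compounds shown here, compound 1, compound 2 and compound 3 are each reported only as a limit, so no step among them can be read. From the compounds shown here alone, how far each lies beyond that limit, and whether the three side chains differ at all here, stays open.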